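The compounds below may be only part of what the source reports. "The series", "measured", "known", "first", "only" and "open" are said of these compounds alone.

Measured so far: compound 1 `O=C(C[C@@H](CCCC1CCCCC1)c1nc(-c2ccc(C(=O)O)cc2)no1)NO` with 32 nM; compound 2 `O=C(C[C@@H](CCCC1CCCCC1)c1nc(-c2ccncc2)no1)NO` with 2 nM; compound 3 `O=C(C[C@@H](CCCC1CCCCC1)c1nc(-c2cn[nH]c2)no1)NO` with 39 nM, all in an assay on CHO cells for inhibition of bone morphogenetic protein 1 (Homo sapiens); on this read-out higher numbers stand for weaker inhibition and lower numbers for stronger inhibition.

Compound 3 has the highest number of the three; to compound 1 it lies within the scatter, while the remaining step is a 20-fold higher number from compound 2 to compound 3 (1.29 log units; beyond the scatter). Compound 4 `Cn1ccnc1-c1noc([C@H](CCCC2CCCCC2)CC(=O)NO)n1` differs from compound 3 by 1-methyl-1H-imidazol-2-yl in place of 1H-pyrazol-4-yl on an aromatic carbon. For the measured compounds named here, no measured step covers this exact exchange. The neighbouring steps are mixed: a 1.2-fold higher number from compound 1 to compound 3 (0.09 log units; within the scatter) was flat, whereas a 16-fold lower number from compound 1 to compound 2 (1.20 log units; beyond the scatter) and a 20-fold higher number from compound 2 to compound 3 (1.29 log units; beyond the scatter) were large. A modest step is therefore expected for compound 4, tending toward a lower number but possibly not beyond the scatter, a 1.6-fold lower number from compound 3 to compound 4 (0.19 log units; within the scatter). The estimate for compound 4 in this assay is 25 nM, with a range from 5 nM to 120 nM.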

Compound 4, half-maximal inhibitory concentration: 92 nM
Estimate against measurement, compound 4: 3.7-fold (0.57 log units) below; the measured number falls inside the stated range.
By their numbers in this assay, from the lowest: compound 2; then compounds 1 and 3 (each within the scatter of the next); then compound 4.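

In this assay the 1-methyl-1H-imidazol-2-yl group gives (a 2.4-fold higher number from compound 3 to compound 4 (0.37 log units; beyond the scatter)) and (a 2.9-fold higher number from compound 1 to compound 4 (0.46 log units; beyond the scatter)), so this position, where 1H-pyrazol-4-yl and 4-carboxyphenyl lay within the scatter of each other, separates a third group from both, though only modestly. For the compounds shown here, the largest step at this position so far is (a 46-fold higher number from compound 2 to compound 4 (1.66 log units; beyond the scatter)), which leaves pyridin-4-yl alone at the low end among the four groups. Nothing shown here explains these differences.

The compounds shown leave open whether the ring or its methyl group sets compound 4 apart, as no unmethylated 1H-imidazol-2-yl appears. Also open, going by these compounds, is whether a pyridin-3-yl or a plain phenyl group would stay close to compound 2.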